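A few compounds are considered here, and "the series" means these few. Any claim that something is new, unique, unknown or untested is made for them only; others in the source may bear on it.

Compound 1 `COc1ccc(/C=C/C(=O)/C=C/c2cc3ccccc3nc2Cl)cc1`: > 10000 nM
Compound 2 `COc1ccc(/C=C/C(=O)/C=C/c2cc3ccccc3nc2Cl)c(OC)c1`: > 10000 nM

Both entries are limits of the assay and not numbers. In a functional assay on HeLa cells (Homo sapiens) for cytotoxicity, read by MTT assay, with a stated time of 48 h (a lower number here means a stronger inhibitor, a higher number a weaker inhibitor), compound 2 gives > 10000 nM, which is a limit. Compound 1 gives > 10000 nM, also a limit. The whole picture so far is therefore (the limit of > 10000 nM in this assay, at which 2 of the 2 values shown sit), and no measured number yet shows how strongly any of these compounds acts.

Compound 3 `COc1cc(OC)c(OC)cc1/C=C/C(=O)/C=C/c1cc2ccccc2nc1Cl` differs from compound 2 by one change: methoxy in place of hydrogen on an aromatic carbon. It swaps a hydrogen for a methoxy group on an aromatic carbon.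

Among the measured compounds shown here, only one measured step bears on this, since it is the same kind of swap: a step that the two limits leave unreadable from compound 1 to compound 2. Its size cannot be read, so it gives neither a size nor a direction to carry over. All that can be taken from it is that one added methoxy group did not bring a measurable value in this assay. Compound 3 is thus expected to stay close to the limit, most likely reported as a limit again. The expected step is a step that the limit leaves unreadable from compound 2 to compound 3, with no real change foreseen. The estimated value for compound 3 is 15000 nM, with an expected range from 5000 nM to 40000 nM.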

Compound 3, half-maximal inhibitory concentration: 5410 nM
Compound 3: middle estimate off by 2.8-fold (0.44 log units), on the high side, within the range that was stated.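

In this assay, among the compounds shown here, compound 3 is the first compound here to give a measured number rather than a limit, so a methoxy group on this aromatic carbon, ortho to a methoxy group and para to a methoxy group, is the first change to bring a readable value: the limit of > 10000 nM in this assay, at which 2 of the 3 values shown sit. The change gives an at least 1.8-fold lower number from compound 2 to compound 3 (0.26 log units; that floor lies within the scatter), and because compound 2 is only a limit, this figure is a floor for the real step, and that floor alone does not rise beyond the usual scatter. For the compounds shown here, the earlier step from compound 1 to compound 2 cannot be read, so it cannot be said whether this position responds differently from the one changed in that step.

From the compounds shown here alone, it remains open whether the readable value depends on methoxy itself or would also appear with a hydroxyl group, a fluorine atom or a longer ethoxy group on this carbon. Equally open, going by these compounds, is whether this methoxy group would have the same effect without the other two methoxy groups on its ring.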